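Working notes: adding a second fluoro to the benzyl group

The compounds below may be only part of what the source reports. "The series", "measured", "known", "first", "only" and "open" are said of these compounds alone.

Measured in an ADME assay on C8166 cells (Homo sapiens) for cytotoxicity, read by MTT assay; on this read-out lower numbers stand for higher toxicity in this test and higher numbers for lower toxicity in this test:
- compound 1 `O=C(O)c1cn(-c2ccccc2)c2ccc(Cc3cccc(Cl)c3F)c(O)c2c1=O`: 388000 nM
- compound 2 `O=C(O)c1cn(Cc2ccc(F)cc2)c2ccc(Cc3cccc(Cl)c3F)c(O)c2c1=O`: 65800 nM

Going by the values given here, compound 2 has the lower of the two numbers so far, 65800 nM. Next comes compound 3 `O=C(O)c1cn(Cc2ccc(F)c(F)c2)c2ccc(Cc3cccc(Cl)c3F)c(O)c2c1=O`, which differs from it as follows: fluoro in place of hydrogen on an aromatic carbon. This is fluoro in place of hydrogen on an aromatic carbon, turning 4-fluorobenzyl into 3,4-difluorobenzyl.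

Among the compounds with values here, no measured step shows this change directly. Within the data shown here, the only step available is a 5.9-fold lower number from compound 1 to compound 2 (0.77 log units; beyond the scatter), and it bears only loosely, since it exchanged phenyl for 4-fluorobenzyl on an aromatic nitrogen rather than adding one fluoro. A much smaller shift is therefore expected, perhaps slightly downward and probably not beyond the scatter. The expected step is a 1.1-fold lower number from compound 2 to compound 3 (0.04 log units; within the scatter). For compound 3 the estimated value is 60000 nM, with an expected range of 26000 nM to 135000 nM.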

Compound 3, half-maximal cytotoxic concentration: 71400 nM
Compound 3: the middle estimate sits 1.2-fold (0.08 log units) below what was measured, within the range that was stated.
By their numbers in this assay, from the lowest: compounds 2 and 3 (each within the scatter of the next); then compound 1.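

In this assay the step of adding a fluoro ortho to the existing fluoro group, turning 4-fluorobenzyl into 3,4-difluorobenzyl, is a 1.1-fold higher number from compound 2 to compound 3 (0.04 log units; within the scatter) and so leaves the number unchanged in practical terms, which shows that this aromatic carbon accepts a fluoro without a real shift in this test. The contrast with phenyl on the aromatic nitrogen persists with the new group, as a 5.4-fold lower number from compound 1 to compound 3 (0.74 log units; beyond the scatter) shows, so this gap is now seen with two fluorinated benzyl groups rather than one. Nothing available explains either the flat step or the persisting gap.

The compounds shown leave open whether a larger group on the same carbon, such as chloro, methoxy or an amine, would also leave the number in place. Unsubstituted benzyl is also absent, so how much of the gap from phenyl belongs to the benzyl group itself and how much to its fluoro remains open.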